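A few compounds are considered here, and "the series" means these few. Any claim that something is new, unique, unknown or untested is made for them only; others in the source may bear on it.

Measured compounds:
- compound 1, `CCc1n[nH]c(CC)c1CCC(=O)NCc1ccc(F)cc1Cl`, in a functional assay for antagonist activity at P2X purinoceptor 7 (Homo sapiens) (a higher number here means a weaker inhibitor, a lower number a stronger inhibitor), compound 1 gives 10 nM
- compound 2, `Cc1n[nH]c(-c2ccccc2)c1CCC(=O)NCc1ccc(F)cc1Cl`; in this assay compound 2 gives only a limit, > 1000 nM
- compound 3, `Cc1c[nH]nc1CCC(=O)NCc1ccc(F)cc1Cl`, in this assay compound 3 gives 398 nM

Among the two values that are numbers, compound 3 stands highest, which here means the weaker inhibitor; compound 1 sits well below it, and that gap lies beyond the usual scatter. Compound 2 contributes only a limit, (the limit of > 1000 nM in this assay, at which 1 of the 3 values shown sits), and so no number.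

Compound 4, `Cc1cc(CCC(=O)NCc2ccc(F)cc2Cl)n(C)n1`, has not yet been measured. It differs from compound 3 in one place: 1,3-dimethyl-1H-pyrazol-5-yl in place of 4-methyl-1H-pyrazol-3-yl on a saturated chain carbon, two bonds along the chain from a carbonyl carbon. Among the measured compounds shown here, no pair of measured compounds shows this same change, so the size of the step can only be expected, not read off. The expectation is that the step from compound 3 to compound 4 in this assay will be small, a 1.5-fold higher number from compound 3 to compound 4 (0.18 log units; within the scatter), or none beyond the scatter, with a lean toward a higher number. Compound 4 is therefore estimated at 600 nM, expected to fall between 150 nM and 2500 nM.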

Compound 4, half-maximal inhibitory concentration: 316 nM
Estimate against measurement, compound 4: 1.9-fold (0.28 log units) above; the range from low to high includes it.
By their numbers in this assay, from the lowest: compound 1; then compounds 4 and 3 (each within the scatter of the next). At a limit, above all of these: compound 2.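

In this assay, placing 1,3-dimethyl-1H-pyrazol-5-yl in place of 4-methyl-1H-pyrazol-3-yl on a saturated chain carbon, two bonds along the chain from a carbonyl carbon, gives a 1.3-fold lower number from compound 3 to compound 4 (0.10 log units; within the scatter) and so no change beyond the scatter. The group that enters has 0 hydrogen-bond donors and the group that leaves has 1 hydrogen-bond donor, so in this pair a ring hydrogen-bond donor is not needed to hold the read-out at this level. No measured property shown here bears on this step.

Going by these compounds, it remains open whether the same exchange would be tolerated on the core of compound 1 at 10 nM in this assay as well. Also open, on these data alone, is how a longer chain, or an amine or a carboxylic acid on the ring, would read at this position.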